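From One Methoxy Group to Three: Expected Paw Edema Inhibition

This account rests on a few compounds, and the source may have more. Where it says the series, first, only, none or still open, it means among the compounds named here.

Of the compounds shown here, three built around a shared core have been tested in a functional assay on the whole organism (strain albino) for inhibition, with Rattus norvegicus as the target, read by paw edema, with stated times of 30 min and 2 h, at a dose of 0.28 mmol/kg by the oral route; on this read-out higher numbers stand for more inhibition at the one dose given (going by the name of the read-out) and lower numbers for less inhibition. Compound 1, `COc1cc(-c2nnc(SCC(=O)Nc3ccc(/C(C)=N/O)cc3)n2-c2ccccc2)cc(OC)c1OC`, gives 62%. Compound 2, `CCn1c(SCC(=O)Nc2ccc(C(C)=O)cc2)nnc1-c1cc(OC)c(OC)c(OC)c1`, gives 50%. Compound 3, `COc1ccc(-c2nnc(SCC(=O)Nc3ccc(C(C)=O)cc3)n2-c2ccccc2)cc1`, gives 42%, the lowest of the three numbers shown, although its gap to compound 2 lies within the usual scatter of repeated measurements, while its gap to compound 1 lies beyond that scatter.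

Compound 4, `COc1cc(-c2nnc(SCC(=O)Nc3ccc(C(C)=O)cc3)n2-c2ccccc2)cc(OC)c1OC`, has not yet been measured. It differs from compound 3 in one place: 3,4,5-trimethoxyphenyl in place of 4-methoxyphenyl on an aromatic carbon. Going by the values given here, no pair of measured compounds differs in exactly this way, so the size of this step cannot be read from a measured example. Compound 1 and compound 2 both carry the 3,4,5-trimethoxyphenyl group and both give higher numbers than compound 3, but each also differs from compound 3 elsewhere, so their values offer only a hint at the direction. A small rise, possibly no larger than the scatter, is expected. The step from compound 3 to compound 4 is estimated at a number 10 percentage points higher from compound 3 to compound 4 (within the scatter). Compound 4 is thus expected to give about 52% in this assay. The expected range for compound 4 runs from 38% to 66%.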

Compound 4, a percentage reported as inhibition, in the whole organism at one dose (the size of the read-out at that dose, not a potency): 54%
Compound 4: middle estimate off by 2 percentage points, on the low side; low and high end bracket the measured number.
By their numbers in this assay, from the lowest: compounds 3, 2, 4 and 1 (each within the scatter of the next, the first and the last beyond it).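

Going by these compounds alone, measured in this assay, replacing 4-methoxyphenyl with 3,4,5-trimethoxyphenyl on the aromatic carbon of the five-membered ring now has a directly observed effect (a number 12 percentage points higher from compound 3 to compound 4 (beyond the scatter)), giving this position a clean one-place comparison that the earlier compounds lacked. Compound 4 also links this series to two other positions: phenyl in place of ethyl on the aromatic nitrogen (a number 4 percentage points higher from compound 2 to compound 4 (within the scatter)) and the ketone in place of the oxime on the aromatic carbon at the far end of the molecule (a number 8 percentage points lower from compound 1 to compound 4 (within the scatter)), and neither change can be separated from the usual scatter at this single dose. None of the information available explains why the larger aryl group goes with more inhibition in this whole-animal test.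

Within the data shown here, with only two groups compared at this position, one step cannot show whether the result depends on the number of methoxy groups or on where they sit. Going by these compounds, a 3,4-dimethoxyphenyl, a 4-hydroxyphenyl or a 4-aminophenyl group in the same place would help to answer that, and it also remains open whether the step would hold with ethyl on the ring nitrogen or with the oxime in place of the ketone.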